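Working notes: a 4-chlorophenyl swap on compound 2

The source may report more compounds than this note shows. Statements on the series, on what has been measured and on what is new or still open speak of the compounds shown alone.

- compound 1 `COc1ccccc1/C=C/C(=O)c1c(OC)cc(O)c(CC=C(C)C)c1O` gives 14600 nM in this series
- compound 2 `COc1cc(OC)c(C(=O)/C=C/c2ccc(O)c(O)c2)c(OC)c1` gives 27500 nM in this series

In a functional assay on HepG2 cells (Homo sapiens) for inhibition, read by MTT assay, with a stated time of 72 h (on this read-out lower numbers stand for stronger inhibition and higher numbers for weaker inhibition), compound 2 stands at 27500 nM and compound 1 at 14600 nM on the two numbers available. These values lie within the usual scatter of each other, so they do not separate the two compounds.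

The next compound, compound 3 `COc1cc(OC)c(C(=O)/C=C/c2ccc(Cl)cc2)c(OC)c1`, has not been measured. It differs from compound 2 by 4-chlorophenyl in place of 3,4-dihydroxyphenyl on a double-bonded chain carbon bound to a double-bonded chain carbon and carries 4-chlorophenyl in place of 3,4-dihydroxyphenyl on a double-bonded chain carbon bound to a double-bonded chain carbon.

Among the measured compounds shown here, no measured pair shows this change, so its size and direction remain open. The expected 1.7-fold lower number from compound 2 to compound 3 (0.24 log units; within the scatter) is toward a lower number, and it is not expected to go beyond the scatter in this assay on present evidence.

For compound 3 the estimate is 16000 nM with an expected range from 6000 nM to 45000 nM at this stage.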

Compound 3, half-maximal inhibitory concentration: 12400 nM
Beside the measured number, compound 3's estimate is 1.3-fold (0.11 log units) above it; measured number inside the range.
By their numbers in this assay, from the lowest: compounds 3, 1 and 2 (each within the scatter of the next, the first and the last beyond it).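

In this assay, 4-chlorophenyl in place of 3,4-dihydroxyphenyl on a double-bonded chain carbon bound to a double-bonded chain carbon gives a 2.2-fold lower number from compound 2 to compound 3 (0.35 log units; beyond the scatter), a modest step. Among the compounds shown here, this is the first pair that differs in one place, and it shows that the number at this position changes with the group carried there. The lower number comes with 4-chlorophenyl, which has no hydrogen-bond donors or acceptors, so in this pair the donors and acceptors of 3,4-dihydroxyphenyl are not required for inhibition at this level.

One pair cannot separate the effect of adding chlorine from that of removing the two hydroxyl groups, and it leaves open how an aminophenyl or carboxyphenyl group would read in the same place. Nothing available here explains the step.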